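Does trifluoromethyl wake an inactive series?

A few compounds are considered here, and "the series" means these few. Any claim that something is new, unique, unknown or untested is made for them only; others in the source may bear on it.

Compound 1 (`C=C[C@@](C)(/C=C/c1ccc(Nc2ccc(OC)cc2)cc1)CCC=C(C)C`): > 36600 nM
Compound 2 (`C=C[C@@](C)(/C=C/c1ccc(Nc2ccc(F)cc2)cc1)CCC=C(C)C`): > 36600 nM
Compound 3 (`C=C[C@@](C)(/C=C/c1ccc(Nc2ccc(C(F)(F)F)cc2)cc1)CCC=C(C)C`): not yet measured

In a functional assay on SEM cells (Homo sapiens) for cytotoxicity, with a stated time of 72 h (a higher number here means that more compound is needed for the effect, a lower number that less compound is needed), compound 2 gives > 36600 nM, which is a limit and not a number. Compound 1 gives > 36600 nM, also a limit. Both measured compounds share one mark: the limit of > 36600 nM in this assay, at which 2 of the 2 values shown sit.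

The next change is trifluoromethyl in place of fluoro on an aromatic carbon, para to a large group. Going by the values given here, the one measured step that bears on it, at the same place, is a step that the two limits leave unreadable from compound 1 to compound 2. It offers no size and no direction, so no step beyond the scatter is expected in this assay. The estimated step is a step that the limit leaves unreadable from compound 2 to compound 3. Compound 3 is expected at 40000 nM, with a range from 18000 nM to 80000 nM.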

Compound 3, half-maximal effective concentration: > 36600 nM
Compound 3: only a limit was reported (the forecaster's own chance of this, stated with the estimate: 80%); the middle value is on the limit's open side.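

Going by these compounds alone, compound 3 also gives only a limit, so no step among compound 1, compound 2 and compound 3 can be read. All three share one mark: the limit of > 36600 nM in this assay, at which 3 of the 3 values shown sit.

Going by these compounds, how their true values compare stays open.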